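Substituents on the benzyloxy ring of a phenoxyethylamine series

This account rests on a few compounds, and the source may have more. Where it says the series, first, only, none or still open, it means among the compounds named here.

compound 1, `COc1cccc(OC)c1OCCNCCOc1ccccc1OCc1ccccc1`: 8.3
compound 2, `COc1cccc(OC)c1OCCNCCOc1ccccc1OCc1ccccc1C`: 7.67
compound 3, `COc1cccc(OC)c1OCCNCCOc1ccccc1OCc1ccccc1[N+](=O)[O-]`: 8.56

All numbers above come from a functional assay on spleen for antagonist activity at Alpha-1B adrenergic receptor (Rattus norvegicus); on this read-out higher numbers stand for higher potency (the scale is a negative logarithm) and lower numbers for lower potency. Compound 1 stands second highest of the three measured numbers. Its nearest neighbour is compound 3, a number 0.26 log units higher from compound 1 to compound 3 (within the scatter); its furthest is compound 2, a number 0.63 log units lower from compound 1 to compound 2 (beyond the scatter). Between compound 2 and compound 3 the gap is larger, a number 0.89 log units higher from compound 2 to compound 3 (beyond the scatter).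

Compound 4, `CCOc1ccc(COc2ccccc2OCCNCCOc2c(OC)cccc2OC)cc1`, differs from compound 1 by ethoxy in place of hydrogen on an aromatic carbon. The two measured steps from compound 1 both place a single group on the same benzyl ring, so both bear on this change, but neither matches it in group or in place: methyl gave a modest loss, nitro a gain within the scatter. Taken together they suggest that a single substituent on this ring moves the number by a modest amount at most, in either direction. With an ethoxy group at a place not yet probed, no step beyond the scatter is expected in this assay. Compound 4 is therefore estimated at 8.1, with a range from 7.5 to 8.7. This amounts to an expected step of a number 0.20 log units lower from compound 1 to compound 4 (within the scatter).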

Compound 4, negative logarithm of the antagonist equilibrium constant: 8.23
Compound 4: the middle estimate sits 0.13 log units below what was measured; measured number inside the range.
By their numbers in this assay, from the lowest: compound 2; then compounds 4, 1 and 3 (each within the scatter of the next, the first and the last beyond it).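

In this assay, ethoxy on the aromatic carbon para to a large group is accommodated, with compound 4 staying within the scatter of the unsubstituted benzyl parent (a number 0.07 log units lower from compound 1 to compound 4 (within the scatter)). Against the other two substituted compounds, the 4-ethoxybenzyl group sits apart on both sides (a number 0.33 log units lower from compound 3 to compound 4 (beyond the scatter); a number 0.56 log units higher from compound 2 to compound 4 (beyond the scatter)), so the loss seen with compound 2 does not follow from any single group on this ring, and compound 4 goes against such a reading. Nothing shown gives a reason for these steps.

Group and place remain tangled across compound 2, compound 3 and compound 4, since the three carry different groups at different places on the ring. On these data alone, whether this place also accepts a longer chain such as hexyloxy, an amine or a carboxylic acid stays open.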